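A few compounds are considered here, and "the series" means these few. Any claim that something is new, unique, unknown or untested is made for them only; others in the source may bear on it.

Measured in a functional assay on HT-29 cells (Homo sapiens) for antiproliferative activity, read by sulforhodamine B assay, with a stated time of 48 h; a higher number here means a weaker inhibitor, a lower number a stronger inhibitor:
- compound 1 `O=C1NCCN1c1ccc(S(=O)(=O)Nc2ccccc2)cc1`: 280 nM
- compound 2 `CCCCOc1ccc(NS(=O)(=O)c2ccc(N3CCNC3=O)cc2)cc1`: 630 nM
- compound 3 `CC(C)Cc1ccc(NS(=O)(=O)c2ccc(N3CCNC3=O)cc2)cc1`: > 1000 nM

The entry for compound 3, > 1000 nM, is a limit and not a number. It stands alone in the series in this respect: the limit of > 1000 nM in this assay, at which 1 of the 3 values shown sits.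

The next compound is compound 4 `CCCCCc1ccc(NS(=O)(=O)c2ccc(N3CCNC3=O)cc2)cc1`, in which butyl replaces isopropyl on a saturated chain carbon bound to an aromatic carbon, so that isobutyl gives way to pentyl: butyl in place of isopropyl on a saturated chain carbon bound to an aromatic carbon.

Among the measured compounds shown here, no measured step makes this exact swap, so the evidence is indirect. Adding butoxy gave a 2.3-fold higher number from compound 1 to compound 2 (0.35 log units; beyond the scatter), and adding isobutyl gave an at least 3.5-fold higher number from compound 1 to compound 3 (0.55 log units; beyond the scatter). Both steps are modest or larger and point the same way, with neither compound going against that direction. The exchange of butoxy for isobutyl gave an at least 1.5-fold higher number from compound 2 to compound 3 (0.20 log units; that floor lies within the scatter), which does not separate the two substituents.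

Compound 4 keeps a saturated chain in the same place as compound 3, so no step beyond the scatter is expected, and no direction can be firmly assigned. The expected change is a number no higher from compound 3 to compound 4 (the limit leaves the size open). A further limit instead of a number would not be surprising.

For compound 4 the estimated value is 1000 nM, with an expected range from 400 nM to 3000 nM.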

Compound 4, half-maximal inhibitory concentration: 990 nM
For compound 4 the middle estimate is 1.0-fold (0.00 log units) above the measured one; the measured number falls inside the stated range.
By their numbers in this assay, from the lowest: compound 1; then compounds 2 and 4 (each within the scatter of the next). At a limit, above all of these: compound 3.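

In this assay, the entry for compound 3 is a limit and not a number: the limit of > 1000 nM in this assay, at which 1 of the 4 values shown sits.

The exchange of isopropyl for butyl gave a number no higher from compound 3 to compound 4 (the limit leaves the size open), so this step has no readable size.

Compound 4 instead gives a saturated chain on this aromatic carbon a measured number, and pentyl in place of hydrogen gave a 3.5-fold higher number from compound 1 to compound 4 (0.55 log units; beyond the scatter), which puts a size on a loss that compound 3 could only bound from one side. Pentyl in place of butoxy gave a 1.6-fold higher number from compound 2 to compound 4 (0.20 log units; within the scatter), so the two substituents are not separated here, and all three substituted compounds stand on the same side of compound 1, with none going against that direction.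

The compounds shown leave open whether a smaller group on this aromatic carbon, such as a methyl, a fluorine or an amine, would stay as close to compound 1 as the unsubstituted core does. They also leave open whether a chain longer than pentyl, or a carboxylic acid at the end of such a chain, would move the number further in the same direction.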